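The compounds below may be only part of what the source reports. "The series", "measured", "known", "first", "only" and "open" are said of these compounds alone.

Measured in a functional assay on MCF7 cells (Homo sapiens) for cytotoxicity, read by MTT assay, with a stated time of 48 h; on this read-out lower numbers stand for stronger inhibition and higher numbers for weaker inhibition:
compound 1 `C/C(=N\NC(=S)Nc1cccc(F)c1)c1ccccn1` gives 9 nM
compound 2 `CC(=NNC(=S)Nc1cccc(I)c1)c1ccccn1` gives 45 nM
compound 3 `C/C(=N\NC(=S)Nc1ccccc1)c1ccccn1` gives 0.18 nM

Compound 3 has the lowest number of the three, well clear of the other two. The next structure is compound 4 `C/C(=N\NC(=S)Nc1cccc(I)c1)c1ccccn1`, with the change iodo in place of hydrogen on an aromatic carbon, meta to a large group. For the measured compounds named here, one measured step bears on this, the large 50-fold lower number from compound 1 to compound 3 (1.70 log units; beyond the scatter), where hydrogen replaces fluoro, so the reverse change raises the number. Compound 2 carries the same iodo group, drawn without a defined double-bond geometry, and gives 45 nM. A large step to a higher number is therefore expected in this assay. For compound 4 the expected value is 45 nM, within a range of 12 nM to 170 nM. The estimated change is a 250-fold higher number from compound 3 to compound 4 (2.40 log units; beyond the scatter).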

Compound 4, half-maximal inhibitory concentration: 45 nM
Beside the measured number, compound 4's estimate shows no gap at the digits printed, within the range that was stated.
By their numbers in this assay, from the lowest: compound 3; then compound 1; then compounds 2 and 4 (each within the scatter of the next).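

In this assay, iodo on this aromatic carbon raises the number sharply (a 250-fold higher number from compound 3 to compound 4 (2.40 log units; beyond the scatter)) and also stands clear of fluoro (a 5.0-fold higher number from compound 1 to compound 4 (0.70 log units; beyond the scatter)), so the numbers rise from hydrogen through fluoro to iodo across compound 3, compound 1 and compound 4. The two iodo entries read alike (no change at the digits printed from compound 2 to compound 4 (within the scatter)), and the only difference between them lies in how the double bond is drawn: the fact that one of compounds 2 and 4 is drawn with a defined configuration and the other without, at the place where they differ
Open, from the compounds shown here alone, is how other groups at this position would read, such as an amine, a carboxylic acid or a methoxy group, and whether the same rise would hold with them.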